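A few compounds are considered here, and "the series" means these few. Any claim that something is new, unique, unknown or untested is made for them only; others in the source may bear on it.

Measured so far: compound 1 `CCCCC(=O)Nc1nc(-c2ccccc2)cc(-c2ccccc2)n1` and compound 2 `CC(C)CC(=O)Nc1nc(-c2ccccc2)cc(-c2ccccc2)n1`.

In an assay on CHO cells for displacement of a labelled ligand from adenosine receptor A1 (Homo sapiens) (on this read-out higher numbers stand for weaker inhibition and lower numbers for stronger inhibition), compound 1 gives 27.6 nM. In this assay compound 2 gives 25.1 nM. Within the data shown here, the single measured step, a 1.1-fold lower number from compound 1 to compound 2 (0.04 log units; within the scatter), swaps one saturated chain for another on the carbonyl carbon, and compound 2 and compound 1 lie within the scatter of each other, so compound 2 stands nowhere apart. Compound 3 `O=C(Nc1nc(-c2ccccc2)cc(-c2ccccc2)n1)C1CCC1` differs from compound 2 by cyclobutyl in place of isobutyl on a carbonyl carbon. Among the measured compounds shown here, only the step from compound 1 to compound 2 bears on this change, and it was small, so no shift beyond the scatter is expected in this assay, a 1.0-fold lower number from compound 2 to compound 3 (0.00 log units; within the scatter). Compound 3 is accordingly estimated at 25 nM, within a range from 10 nM to 60 nM.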

Compound 3, inhibition constant: 107 nM
Beside the measured number, compound 3's estimate is 4.3-fold (0.63 log units) below it, outside the stated range (above it).
By their numbers in this assay, from the lowest: compounds 2 and 1 (each within the scatter of the next); then compound 3.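

In this assay, cyclobutyl on the carbonyl carbon gives a 4.3-fold higher number from compound 2 to compound 3 (0.63 log units; beyond the scatter), and in place of butyl it gives a 3.9-fold higher number from compound 1 to compound 3 (0.59 log units; beyond the scatter). Among these three compounds, the position therefore separates the ring from both open chains, whereas butyl and isobutyl lie within the scatter of each other. No measurement offered here accounts for this difference.

As far as these compounds go, whether cyclopropyl, cyclopentyl or cyclohexyl would follow cyclobutyl remains open. So does whether a longer chain or an amine on the chain would stay with the open chains.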